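Solubility at the Amide Aryl Group: Thiophene to Difluorophenyl

The compounds below may be only part of what the source reports. "The series", "measured", "known", "first", "only" and "open" are said of these compounds alone.

Compound 1 `CN1CCC(C(=O)N2Cc3c(NC(=O)c4ccccc4)n[nH]c3C2(C)C)CC1`: > 225000 nM (a limit of the assay)
Compound 2 `CN1CCC(C(=O)N2Cc3c(NC(=O)c4cccs4)n[nH]c3C2(C)C)CC1`: 155000 nM

The two measured compounds share one core and differ only in the group on the carbonyl carbon of the amide. In a physicochemical assay for solubility, at pH 7 (on this read-out higher numbers stand for higher solubility and lower numbers for lower solubility), compound 1 sits at the limit of > 225000 nM in this assay, at which 1 of the 2 values shown sits, so its value is a limit and not a number. In this assay, among the compounds with values here, compound 2 gives 155000 nM, the only number among the values shown. The measured step reads an at least 1.4-fold lower number from compound 1 to compound 2 (0.16 log units; that floor lies within the scatter).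

Compound 3 `CN1CCC(C(=O)N2Cc3c(NC(=O)c4cc(F)cc(F)c4)n[nH]c3C2(C)C)CC1` is not yet measured. It differs from compound 2 by 3,5-difluorophenyl in place of thiophen-2-yl on a carbonyl carbon. Within the data shown here, only the step from compound 1 to compound 2 bears on this change, and it was small. A step of a 1.3-fold lower number from compound 2 to compound 3 (0.11 log units; within the scatter) is therefore expected, within the scatter. For compound 3 a value of 120000 nM is estimated, with a range from 40000 nM to 300000 nM.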

Compound 3, solubility: > 225000 nM
Compound 3 ended at the assay's limit; the forecaster's own chance of this, stated with the estimate: 15%; middle value at least 1.8-fold (0.27 log units) away from the limit.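

Setting 3,5-difluorophenyl in place of thiophen-2-yl on the carbonyl carbon gives an at least 1.4-fold higher number from compound 2 to compound 3 (0.16 log units; that floor lies within the scatter), so in this assay a ring carrying fluorine at this place shows no loss against compound 2. Compound 3 gives > 225000 nM, which is a limit and not a number, and compound 1 stands at the same limit: the limit of > 225000 nM in this assay, at which 2 of the 3 values shown sit. The step from compound 1 to compound 3 cannot be read, so phenyl and 3,5-difluorophenyl cannot be put in order here.

From the compounds shown here alone, whether the fluorine atoms change the read-out at all against plain phenyl therefore stays open. Also open, going by these compounds, is how the read-out responds on this carbonyl carbon to a pyridine ring, or to a group without an aromatic ring, such as cyclohexyl or a longer alkyl chain.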